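Notes on a methyl step from compound 1

A few compounds are considered here, and "the series" means these few. Any claim that something is new, unique, unknown or untested is made for them only; others in the source may bear on it.

- Compound 1 `c1ccc2[nH]c(-n3cccn3)cc2c1`: > 100000 nM, a limit
- Compound 2 `COc1ccc2[nH]c3c4cn[nH]c4c4c(c3c2c1)C(=O)NC4=O`: > 100000 nM, a limit

Both entries come from a functional assay on PC-3 cells (Homo sapiens) for cytotoxicity, read by MTT assay, with a stated time of 72 h; on this read-out lower numbers stand for stronger inhibition and higher numbers for weaker inhibition. Compound 1 gives only a limit in this assay, and no number is available for it. Among the measured compounds shown here, the same holds for compound 2, so the series so far amounts to the limit of > 100000 nM in this assay, at which 2 of the 2 values shown sit.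

Compound 3 `Cc1ccc2[nH]c(-n3cccn3)cc2c1` keeps the core of compound 1 and has methyl in place of hydrogen on an aromatic carbon. For the measured compounds named here, no measured pair shows what such a change does in this assay. No step beyond the scatter is expected, in either direction, and a further limit is a likely outcome. The estimated step of a number no higher from compound 1 to compound 3 (the limit leaves the size open) is expected to stay within the scatter. For compound 3 the expected value is 100000 nM, with an estimated range of 40000 nM to 150000 nM.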

Compound 3, half-maximal inhibitory concentration: > 100000 nM
Compound 3: only a limit was reported (the forecaster's own chance of this, stated with the estimate: 75%); the middle value sits exactly at the limit.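

In this assay, among the compounds shown here, compound 3 gives > 100000 nM, a limit, and with compound 1 also reported only as a limit, no step between compound 1 and compound 3 can be read. The compounds shown leave open what methyl in place of hydrogen on an aromatic carbon does in this assay, since every value is a limit: the limit of > 100000 nM in this assay, at which 3 of the 3 values shown sit.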